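Chloro in place of hydrogen on compound 2

The source may hold more compounds than are shown below. What is called first, only, known or untested is meant among the compounds shown, and "the series" means these compounds.

In a functional assay on HCT-116 cells (Homo sapiens) for antiproliferative activity, read by MTT assay, with a stated time of 72 h (on this read-out higher numbers stand for weaker inhibition and lower numbers for stronger inhibition), three compounds have been measured so far. Compound 1 `COc1ccc(OCCCON2C(N)=NC(N)=NC23CCOCC3)cc1` gives 1500 nM, compound 3 `Cc1cc(C)cc(OCCCON2C(N)=NC(N)=NC23CCOCC3)c1` gives 190 nM, and compound 2 `NC1=NC2(CCSCC2)N(OCCCOc2cccc(Cl)c2)C(N)=N1` gives 1 nM. Compound 2 has the lowest number of the three, and its gaps to both others lie beyond the scatter. It differs from each of them in the core as well as in the aromatic ring, so those gaps cannot be assigned to either part.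

Compound 4 `NC1=NC2(CCSCC2)N(OCCCOc2cccc(Cl)c2Cl)C(N)=N1` is the next case: chloro in place of hydrogen on an aromatic carbon of compound 2, taking 3-chlorophenyl to 2,3-dichlorophenyl, (chloro in place of hydrogen on an aromatic carbon). The incoming chloro is ortho to a chloro group and ortho to a large group.

Among the compounds with values here, only one measured step touches the aromatic ring: a 7.9-fold lower number from compound 1 to compound 3 (0.90 log units; beyond the scatter). That step is beyond the scatter, but it was taken on the other core and involves no chloro group, so it offers only a rough width for changes on this ring. Within the data shown here, no measured step adds a chloro group. A small move toward a higher number is expected, with the upper side left wide. The estimated change is a 2.0-fold higher number from compound 2 to compound 4 (0.30 log units; within the scatter). For compound 4 the expected value is 2 nM, with an estimated range of 0.4 nM to 15 nM.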

Compound 4, half-maximal inhibitory concentration: 1 nM
Estimate against measurement, compound 4: 2.0-fold (0.30 log units) above; the range from low to high includes it.
By their numbers in this assay, from the lowest: compounds 2 and 4 (each within the scatter of the next); then compound 3; then compound 1.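

In this assay, chloro in place of hydrogen on an aromatic carbon, ortho to a chloro group and ortho to a large group, gives no change at the digits printed from compound 2 to compound 4 (within the scatter), so taking 3-chlorophenyl to 2,3-dichlorophenyl leaves the number where it stood. Within the data shown here, this is the first step on the core of compound 2 and the first to add a chloro group; the only earlier ring step, a 7.9-fold lower number from compound 1 to compound 3 (0.90 log units; beyond the scatter), lies beyond the scatter but was taken on another core and with different ring groups, so it said nothing about this carbon. At this position, on this core, the added chloro group thus costs nothing measurable in this read-out, although nothing shown explains this result.

Still open, going by these compounds, is whether the same chloro group would leave the number unchanged on the core of compound 1, where the numbers are much higher and a shift might read differently. Also open, on these data alone, is how far this carbon accepts other groups, such as an amine or a carboxylic acid in place of the chloro group, and whether a longer chain carrying the aromatic ring would hold the number.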